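Nitro to Bromo on Two Cores in an Antiproliferative Series

The compounds below may be only part of what the source reports. "The series", "measured", "known", "first", "only" and "open" are said of these compounds alone.

Of the compounds shown here, three have been measured in a functional assay on CCRF-CEM cells (Homo sapiens) for antiproliferative activity, read by fluorescence and resazurin assay, with a stated time of 48 h; on this read-out lower numbers stand for stronger inhibition and higher numbers for weaker inhibition. Compound 1 `CCOc1ccc2nc(Cl)c(/C=N/NC(=O)c3cc4cc([N+](=O)[O-])ccc4oc3=O)cc2c1` gives 15700 nM. Compound 2 `CCOc1ccc2nc(Cl)c(/C=N/NC(=O)c3cc4cc(Br)ccc4oc3=O)cc2c1` differs from compound 1 only in one place, (bromo in place of nitro on an aromatic carbon), and in this assay compound 2 gives 12900 nM. The step of a 1.2-fold lower number from compound 1 to compound 2 (0.09 log units; within the scatter) is therefore small. Compound 3 `Cc1noc(NS(=O)(=O)c2ccc(NC(=O)c3cc4cc([N+](=O)[O-])ccc4oc3=O)cc2)c1C` carries the same nitro group but on a different core; how the core of compound 3 differs from the core of compound 1 is not broken down here. In this assay compound 3 gives 14300 nM, a number that sits within the scatter of both compound 1 and compound 2, so no order among the three can be drawn.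

Compound 4 `Cc1noc(NS(=O)(=O)c2ccc(NC(=O)c3cc4cc(Br)ccc4oc3=O)cc2)c1C` is not yet measured. It stands to compound 3 as compound 2 stands to compound 1: bromo in place of nitro on an aromatic carbon. The two place descriptions are identical word for word, so this is the same change, made for the second time among these compounds.

Among the measured compounds shown here, the expectation for compound 4 rests on the single earlier instance, the step of a 1.2-fold lower number from compound 1 to compound 2 (0.09 log units; within the scatter), which lay within the scatter. Compound 4 is therefore expected to show a step of about a 1.2-fold lower number from compound 3 to compound 4 (0.08 log units; within the scatter), scarcely distinguishable from no change. On that basis compound 4 is estimated at 12000 nM in this assay, with a likely range from 6000 nM to 25000 nM.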

Compound 4, half-maximal inhibitory concentration: 14600 nM
Beside the measured number, compound 4's estimate is 1.2-fold (0.09 log units) below it, within the range that was stated.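

On the core of compound 3, bromo in place of nitro on an aromatic carbon leaves the number in this assay essentially where it was, with a 1.0-fold higher number from compound 3 to compound 4 (0.01 log units; within the scatter). Set beside the first instance of the same change, the step carries from one core to the other with no difference that can be read: the same change on two cores in this assay, a 1.2-fold lower number (0.09 log units; within the scatter) from compound 1 to compound 2 and a 1.0-fold higher number (0.01 log units; within the scatter) from compound 3 to compound 4, 1.2-fold (0.09 log units) apart, within the scatter of two such steps. Among the compounds shown here, this shows only that the exchange of these two groups made no readable difference on either of these two cores in this one cell assay; with both steps within the scatter, it shows no shared effect of the change, and it does not show that the same would hold on any further core or in any other assay.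

The compounds shown carry only nitro or bromo at this aromatic carbon, so it remains open whether a plain hydrogen, an amine, a methoxy group or a carboxylic acid there would move the number at all. As far as these compounds go, it is equally open whether the number responds to changes elsewhere in the molecules, such as replacing the ethoxy group or the chloro group of compound 1 with a longer chain or an amine.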